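A few compounds are considered here, and "the series" means these few. Any claim that something is new, unique, unknown or untested is made for them only; others in the source may bear on it.

Measured in an ADME assay on Vero cells (Chlorocebus sabaeus) for cytotoxicity, read by MTT assay, with a stated time of 96 h; a higher number here means that more compound is tolerated, a lower number that less compound is tolerated:

Compound 1 `CC(=O)c1ccc2[nH]c(-c3ccc(C(F)(F)F)cc3)nc2c1`: > 100000 nM
Compound 2 `C/C(=N\NC(N)=O)c1ccc2[nH]c(-c3ccccc3)nc2c1`: > 100000 nM
Compound 3 `C/C(=N\NC(N)=O)c1ccc2[nH]c(-c3ccc(Cl)cc3)nc2c1`: > 100000 nM

Each of these three results is a limit and not a number.

Compound 3 stands at a limit, > 100000 nM. The other two measured compounds share it, as the data show: the limit of > 100000 nM in this assay, at which 3 of the 3 values shown sit. The three therefore cannot be ranked against one another.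

The next step leads to compound 4 `C/C(=N\NC(N)=O)c1ccc2[nH]c(-c3ccc(C(F)(F)F)cc3)nc2c1`, which has trifluoromethyl in place of chloro on an aromatic carbon, para to a large group: trifluoromethyl in place of chloro on an aromatic carbon.

Within the data shown here, only one measured step bears on this position, and it is a step that the two limits leave unreadable from compound 2 to compound 3. It put chloro in place of hydrogen on an aromatic carbon, and it gives no size to carry forward. Compound 1 also carries trifluoromethyl, and its result is likewise a limit, > 100000 nM. Among the measured compounds shown here, no measured compound in this small set has a number in this assay, so no step beyond the scatter is expected, and no direction can be given.

The estimated step is a number no higher from compound 3 to compound 4 (the limit leaves the size open). A result at the same limit is the most likely outcome. For compound 4 the expected value is 100000 nM, with an estimated range from 40000 nM to 200000 nM.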

Compound 4, half-maximal cytotoxic concentration: > 100000 nM
Compound 4: a limit, no number (the forecaster's own chance of this, stated with the estimate: 75%); the middle value sits exactly at the limit.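

In this assay compound 4 gives > 100000 nM, which is a limit and not a number. No step can be read from compound 1, compound 2 or compound 3 to compound 4, since all four stand at one limit: the limit of > 100000 nM in this assay, at which 4 of the 4 values shown sit.

The compounds shown leave open where the half-maximal cytotoxic concentration of each lies, and how the four rank in this assay.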